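The source may hold more compounds than are shown below. What is called first, only, known or untested is meant among the compounds shown, and "the series" means these compounds.

Compound 1 `O=S(=O)(Nc1ccc(-c2nc3ccccc3o2)cc1)c1cccc(F)c1` joins a sulfonamide to the shared core. In an assay on isolated protein for inhibition of malate dehydrogenase, mitochondrial (Sus scrofa), with stated times of 45 min and 30 min (on this read-out lower numbers stand for stronger inhibition and higher numbers for weaker inhibition), compound 1 gives > 63000 nM, which is a limit of the assay rather than a number. Compound 2 `C=Cc1ccc(S(=O)(=O)Nc2ccc3oc(-c4ccccc4)nc3c2)cc1` and compound 3 `COc1cccc(S(=O)(=O)Nc2ccc3oc(-c4ccccc4)nc3c2)c1` carry sulfonamides of the same kind. In this assay compound 2 gives > 63000 nM, again a limit. In this assay compound 3 gives > 63000 nM, also a limit. For the measured compounds named here, the one single change measured here, a step that the two limits leave unreadable from compound 2 to compound 3, therefore has no readable size. Going by the values given here, every value shown sits at the limit of > 63000 nM in this assay, at which 3 of the 3 values shown sit, so compound 1 stands with the others at the edge of what the assay reports, and no measured step shows any change at the sulfonyl sulfur leaving that edge.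

Compound 4 `O=S(=O)(Nc1ccc(-c2nc3ccccc3o2)cc1)c1ccc(Cl)cc1` differs from compound 1 by 4-chlorophenyl in place of 3-fluorophenyl on a sulfonyl sulfur. Among the compounds with values here, no measured step bears directly on this change; the nearest, a step that the two limits leave unreadable from compound 2 to compound 3, is unreadable, and the three values shown give no hint of a direction. The expected step is therefore one within the scatter, a step that the limit leaves unreadable from compound 1 to compound 4, with compound 4 most likely again reaching only the limit. The estimate for compound 4 in this assay is 100000 nM, with a range from 30000 nM to 300000 nM.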

Compound 4, half-maximal inhibitory concentration: > 63000 nM
Compound 4 was reported as a limit (the forecaster's own chance of this, stated with the estimate: 90%); the middle value lies beyond the limit too.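

In this assay compound 4 gives > 63000 nM, a limit and not a number, so the change from compound 1 to compound 4 has no readable size. All the compounds shown stand at the same edge: the limit of > 63000 nM in this assay, at which 4 of the 4 values shown sit. Still open, as far as these compounds go, is whether any group on the sulfonyl sulfur can give a readable value.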